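Adding chloro to a sulfonamide-bearing pyrazole: an expected step

The compounds below may be only part of what the source reports. "The series", "measured", "known", "first", "only" and "open" are said of these compounds alone.

Measured so far:
compound 1, `COc1ccc(OC)c(-c2cc(-c3ccc(Cl)cc3)nn2-c2ccccc2)c1`, gives 40600 nM in a functional assay on cells (Cancer cell lines, Homo sapiens) for cytotoxicity, read by sulforhodamine B assay, with a stated time of 48 h; a higher number here means a weaker inhibitor of growth, a lower number a stronger inhibitor of growth.
compound 2, `COc1ccc(OC)c(-c2cc(-c3ccccc3)nn2-c2ccc(S(=O)(=O)NC(C)=O)cc2)c1`, gives 15300 nM in this assay.

Of the two numbers, compound 2 holds the lower one, and its gap to compound 1 lies beyond the usual scatter. For the measured compounds named here, compound 1 and compound 2 differ in more than one place, so no single step between them can be read off.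

Compound 3, `COc1ccc(OC)c(-c2cc(-c3ccc(Cl)cc3)nn2-c2ccc(S(=O)(=O)NC(C)=O)cc2)c1`, is a new compound. It differs from compound 2 by chloro in place of hydrogen on an aromatic carbon. Going by the values given here, no measured pair shows the effect of this change on the shared core, so the expectation rests on compound 2 alone. The step from compound 2 to compound 3 is expected to be small, most likely within the scatter, with a lean toward a somewhat lower number: a 1.5-fold lower number from compound 2 to compound 3 (0.18 log units; within the scatter). Compound 3 is therefore expected to give about 10000 nM in this assay, with a range from 4000 nM to 30000 nM.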

Compound 3, concentration for 50% growth inhibition: 17700 nM
Compound 3: the middle estimate sits 1.8-fold (0.25 log units) below what was measured; the range from low to high includes it.
By their numbers in this assay, from the lowest: compounds 2 and 3 (each within the scatter of the next); then compound 1.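

In this assay, for the compounds shown here, going from phenyl to 4-chlorophenyl on the acetylsulfamoyl-bearing compounds gives a 1.2-fold higher number from compound 2 to compound 3 (0.06 log units; within the scatter), so at this position the chloro produces no step that can be told apart from repeat measurement. Going by these compounds alone, the result also provides the first single-place reading of the acetylsulfamoyl group: with the 4-chlorophenyl kept in place, adding this group gives a 2.3-fold lower number from compound 1 to compound 3 (0.36 log units; beyond the scatter), a modest step. No measurement shown explains either step.

An amine or a carboxylic acid in place of the chloro might or might not move the number beyond the scatter. Also open, from the compounds shown here alone, is whether the acetylsulfamoyl step would hold on the shared core with plain phenyl instead of 4-chlorophenyl.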